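Methyl for Carboxy on a Weak Inhibitor Series

A few compounds are considered here, and "the series" means these few. Any claim that something is new, unique, unknown or untested is made for them only; others in the source may bear on it.

Measured compounds:
compound 1, `O=C(O)c1ccc2[nH]c(=O)c(=O)oc2c1`, 16000 nM
compound 2, `COc1cc2[nH]c(=O)c(=O)oc2cc1OC`, 30000 nM
compound 3, `COc1cccc2[nH]c(=O)c(=O)oc12`, 7000 nM

Of the compounds shown here, three sharing one core have been tested in a functional assay with Rattus norvegicus as the target; a lower number here means a stronger inhibitor, a higher number a weaker inhibitor. Compound 1 gives 16000 nM, a number that sits close to that of compound 2, which gives 30000 nM, the two lying within the usual scatter of each other. Compound 3, with 7000 nM, has a lower number than compound 1, a gap that goes beyond the scatter. Within this small set, then, compound 1 is among the weaker inhibitors, and no compound of the three reaches a strong value.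

The next compound, compound 4, `Cc1ccc2[nH]c(=O)c(=O)oc2c1`, has not been measured in this assay. It differs from compound 1 in one place: methyl in place of carboxy on an aromatic carbon. Within the data shown here, no measured pair shows this same change, so no step of known size is available for it. With the whole set spanning only a modest range, the expectation is for a step of small size in this assay, from compound 1 to compound 4, of about a 1.6-fold lower number from compound 1 to compound 4 (0.20 log units; within the scatter), if anything towards a lower number. Compound 4 is thus estimated at 10000 nM, with a range from 3000 nM to 40000 nM.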

Compound 4, half-maximal inhibitory concentration: 32000 nM
Beside the measured number, compound 4's estimate is 3.2-fold (0.51 log units) below it; the measured number falls inside the stated range.
By their numbers in this assay, from the lowest: compound 3; then compounds 1, 2 and 4 (each within the scatter of the next).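

In this assay, among these compounds, methyl in place of carboxy on this aromatic carbon gives a 2.0-fold higher number from compound 1 to compound 4 (0.30 log units; within the scatter) and so provides the first comparison in the set between two compounds that differ in one place. At this position, meta to one fused ring and para to another, the two groups cannot be told apart, even though carboxy brings a hydrogen-bond donor and acceptor and methyl brings neither. Nothing available explains this result.

Going by these compounds, whether an amine, a chlorine atom or a longer chain on this same carbon would stand apart from carboxy and methyl remains open. Also open, on these data alone, is whether the same change would give a comparable step on another aromatic carbon of the shared core, as this single pair cannot show it.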